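Methylsulfanyl for methyl on the aryl ring of the triazole series

The compounds below may be only part of what the source reports. "The series", "measured", "known", "first", "only" and "open" are said of these compounds alone.

Among the compounds with values here, compound 1 `COc1cc(-n2ncnc2-c2ccc(C)cc2)cc(OC)c1OC` gives 1100 nM in a functional assay on A549 cells (Homo sapiens) for antiproliferative activity, read by MTT assay, with a stated time of 72 h (a higher number here means a weaker inhibitor, a lower number a stronger inhibitor), the only number so far in the set. Compound 2 `COc1cc(-c2ncnn2-c2cccc([N+](=O)[O-])c2)cc(OC)c1OC` in this assay reaches only the limit of > 10000 nM, which is a limit and not a number, as noted in the limit of > 10000 nM in this assay, at which 1 of the 2 values shown sits. Compound 3 `COc1cc(-n2ncnc2-c2ccc(SC)cc2)cc(OC)c1OC` is not yet measured; it differs from compound 1 by methylsulfanyl in place of methyl on an aromatic carbon. Within the data shown here, no measured step with this change exists here, so the expectation rests on compound 1 alone, with no step expected beyond the scatter, as a 1.2-fold lower number from compound 1 to compound 3 (0.09 log units; within the scatter) indicates. Compound 3 is estimated at 900 nM in this assay, with a range from 300 nM to 2700 nM.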

Compound 3, half-maximal inhibitory concentration: 800 nM
Compound 3: middle estimate off by 1.1-fold (0.05 log units), on the high side; low and high end bracket the measured number.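

In this assay, within the data shown here, methylsulfanyl in place of methyl on the aryl ring gives a 1.4-fold lower number from compound 1 to compound 3 (0.14 log units; within the scatter) and is the first measured step. In this one pair, the position takes a sulfur-linked group with no step beyond the scatter. Nothing measured here bears on why the two values sit so close. On these data alone, how an amine, a carboxylic acid or a longer chain such as ethylsulfanyl would read at this place remains open. Also open, as far as these compounds go, is whether the same change behaves alike on other members.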